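The source may hold more compounds than are shown below. What is called first, only, known or untested is meant among the compounds shown, and "the series" means these compounds.

Measured compounds in this series:
compound 1 `O=C(O)c1cc(-n2c(-c3ccccc3)cc3c2CCCC3)ccc1O`: >= 60%
compound 2 `COc1ccc(-n2c(-c3ccccc3)cc3c2CCCC3)cc1C(=O)O`: 40%
compound 3 `COc1ccc(-c2cc3c(n2-c2ccc(O)c(C(=O)O)c2)CCCC3)cc1`: 50%

The read-out is a functional assay on the whole organism (strain Wistar) for inhibition, with Rattus norvegicus as the target, read by paw edema, with stated times of 30 min and 3 h, at a dose of 200 mg/kg by the oral route; a lower number here means less inhibition, a higher number more inhibition at the dose given (going by the name of the read-out). For compound 1 the value >= 60% is a limit of the assay, not a number. Among the two numbers, compound 3 gives 50% and compound 2 gives 40%, the two lying within the scatter of each other. The measured steps are a number at least 20 percentage points lower from compound 1 to compound 2 (beyond the scatter) and a number at least 10 percentage points lower from compound 1 to compound 3 (that floor lies within the scatter). Compound 4 `COc1cccc(-c2cc3c(n2-c2ccc(O)c(C(=O)O)c2)CCCC3)c1` differs from compound 3 by 3-methoxyphenyl in place of 4-methoxyphenyl on an aromatic carbon. Neither measured step moves the methoxy around the phenyl in this way, so they bear only loosely on it; the expectation is a number 5 percentage points lower from compound 3 to compound 4 (within the scatter), a step not beyond the scatter. Compound 4 is therefore estimated at 45%, within 25% to 65%.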

Compound 4, a percentage reported as inhibition, in the whole organism at one dose (the size of the read-out at that dose, not a potency): 20%
Estimate against measurement, compound 4: 25 percentage points above, and the stated range ends above it.
By their numbers in this assay, from the lowest: compound 4; then compounds 2 and 3 (each within the scatter of the next). At a limit, above all of these: compound 1.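

In this assay, 3-methoxyphenyl in place of 4-methoxyphenyl, on the aromatic carbon next to the ring nitrogen, gives a number 30 percentage points lower from compound 3 to compound 4 (beyond the scatter), so with the same atoms joined differently, where the methoxy sits on this phenyl changes the read-out. Methoxy in place of hydrogen on that phenyl now gives a number at least 40 percentage points lower from compound 1 to compound 4 (beyond the scatter). That step has only a floor, since compound 1 stands at a limit of the assay, not a number: the limit of >= 60% in this assay, at which 1 of the 4 values shown sits.

On these data alone, whether a hydroxy or an amine in place of the methoxy of 3-methoxyphenyl would give the same read-out stays open.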